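Pyridin-4-yl in place of 1-(aminomethyl)-1-methylethyl

The source may report more compounds than this note shows. Statements on the series, on what has been measured and on what is new or still open speak of the compounds shown alone.

In a physicochemical assay for lipophilicity, read by HPLC, measured as chromatographic lipophilicity, at pH 7.4 (a lower number here means a more polar compound, a higher number a more lipophilic compound), compound 2 `CC(C)(CN)C(=O)N1N=CCC1c1ccccc1` gives 1.4 and stands lowest of the two numbers, while compound 1 `O=C(c1cccnc1)N1N=CCC1c1ccccc1` gives 2.7 on the same scale. Compound 3 `O=C(c1ccncc1)N1N=CCC1c1ccccc1` has not yet been measured. It carries pyridin-4-yl in place of 1-(aminomethyl)-1-methylethyl on a carbonyl carbon and keeps the shared core. Among the measured compounds shown here, one measured step bears on this change: a number 1.30 log units lower from compound 1 to compound 2 (beyond the scatter) is large and beyond the scatter, and in it pyridin-3-yl gives way to the same 1-(aminomethyl)-1-methylethyl on that carbonyl carbon. For the measured compounds named here, no measurement yet shows what pyridin-4-yl itself does, so that step, read in reverse, is the only guide. The expected change is a number 1.20 log units higher from compound 2 to compound 3 (beyond the scatter) in the upward direction, similar in size and beyond the scatter. Compound 3 is estimated at 2.6 in this assay with 2.2 to 3 as the expected range.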

Compound 3, distribution coefficient: 2.7
Estimate against measurement, compound 3: 0.10 log units below; measured number inside the range.
By their numbers in this assay, from the lowest: compound 2; then compounds 1 and 3 (each within the scatter of the next).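

In this assay pyridin-4-yl on the carbonyl carbon, in place of 1-(aminomethyl)-1-methylethyl, gives a number 1.30 log units higher from compound 2 to compound 3 (beyond the scatter), so the large difference first seen with pyridin-3-yl also appears with a second pyridine attachment. The exchange of pyridin-3-yl for pyridin-4-yl gives no change at the digits printed from compound 1 to compound 3 (within the scatter), which shows that in this assay the two pyridinyl groups cannot be told apart at this position, something that compound 1 and compound 2 alone could not show.

Going by these compounds, it remains open whether pyridin-2-yl, a plain phenyl ring or a chain ending in a carboxylic acid on the same carbonyl carbon would fall with the two pyridinyl compounds or nearer to compound 2. Nothing available explains why the pyridinyl groups and 1-(aminomethyl)-1-methylethyl differ as they do, or why the two pyridinyl groups match.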